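Replacing Nitro with Methoxy in a Cytotoxicity Series

The source may hold more compounds than are shown below. What is called first, only, known or untested is meant among the compounds shown, and "the series" means these compounds.

Measured in a functional assay on MCF7 cells (Homo sapiens) for cytotoxicity, read by MTT assay, with a stated time of 72 h; a higher number here means a weaker inhibitor, a lower number a stronger inhibitor:
- compound 1 `CCC[S+]([O-])CCCCN=C=S`: 5960 nM
- compound 2 `[O-][S+](CCCCN=C=S)Cc1ccccc1`: 3300 nM
- compound 3 `O=[N+]([O-])c1ccc(C[S+]([O-])CCCCN=C=S)cc1`: 7770 nM

Compound 1, at 5960 nM, and compound 3, at 7770 nM, lie within the scatter of each other, while compound 2 shows the lower number of 3300 nM. Compound 4 `COc1ccc(C[S+]([O-])CCCCN=C=S)cc1` differs from compound 3 by one change: methoxy in place of nitro on an aromatic carbon. This places methoxy in place of nitro on an aromatic carbon, para to a large group.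

Among the measured compounds shown here, one measured step bears on this change: a 2.4-fold higher number from compound 2 to compound 3 (0.37 log units; beyond the scatter). That modest step, which goes beyond the scatter, accompanies nitro in place of hydrogen. For the measured compounds named here, no measured compound carries methoxy, so the data show only what happens when nitro enters, and the effect of methoxy remains an inference. Losing nitro is therefore expected to bring a modest move toward a lower number in this assay, of about the same size as that step. The expected change is a 2.1-fold lower number from compound 3 to compound 4 (0.32 log units; beyond the scatter). For compound 4, the estimated value is 3700 nM, with an expected range of 1900 nM to 7500 nM.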

Compound 4, half-maximal inhibitory concentration: 8890 nM
Compound 4: middle estimate off by 2.4-fold (0.38 log units), on the low side, and the stated range ends below it.
By their numbers in this assay, from the lowest: compounds 2, 1, 3 and 4 (each within the scatter of the next, the first and the last beyond it).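

In this assay, putting methoxy in place of nitro on an aromatic carbon, para to a large group, gives a 1.1-fold higher number from compound 3 to compound 4 (0.06 log units; within the scatter), so the two groups cannot be told apart at this position. Set against hydrogen, methoxy gives a 2.7-fold higher number from compound 2 to compound 4 (0.43 log units; beyond the scatter) and nitro gives a 2.4-fold higher number from compound 2 to compound 3 (0.37 log units; beyond the scatter), so the higher number is not peculiar to nitro: in these compounds, both groups at this position go with a higher number than hydrogen does. The data shown offer no explanation for this shared result.

The compounds shown leave open whether any group at this position can match or improve on the hydrogen of compound 2. An amine or a carboxylic acid here would test whether the rise holds beyond nitro and methoxy.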